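Swapping 3-hydroxyphenyl for tert-butyl on the shared core

The compounds below may be only part of what the source reports. "The series", "measured", "known", "first", "only" and "open" are said of these compounds alone.

Among the measured compounds shown here, in a functional assay on A549 cells (Homo sapiens) for antiproliferative activity, read by MTT assay, with a stated time of 72 h (on this read-out lower numbers stand for stronger inhibition and higher numbers for weaker inhibition), compound 1 `O=C1O[C@H]([C@@H](O)Cn2cc(-c3cccc(O)c3)nn2)C(OCc2ccccc2)=C1OCc1ccccc1` gives 59900 nM, the only actual number so far. Compound 2 `CCCCCc1ccc(-c2cn(C/C=C3\OC(=O)C(OCc4ccccc4)=C3OCc3ccccc3)nn2)cc1` returns only a limit of the assay, > 100000 nM. Compound 3 `CC(C)(C)c1cn(C[C@H](O)[C@H]2OC(=O)C(OCc3ccccc3)=C2OCc2ccccc2)nn1` keeps the core of compound 1 but carries tert-butyl in place of 3-hydroxyphenyl on an aromatic carbon. For the measured compounds named here, no measured step isolates this change, so the expectation starts from compound 1 at 59900 nM. In this assay the expected step is a 1.2-fold higher number from compound 1 to compound 3 (0.07 log units; within the scatter), a slight weakening at most and nothing beyond the scatter. For compound 3 the estimated value is 70000 nM, with an expected range of 25000 nM to 150000 nM.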

Compound 3, half-maximal inhibitory concentration: 34000 nM
For compound 3 the middle estimate is 2.1-fold (0.31 log units) above the measured one; the measured number falls inside the stated range.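

In this assay, the exchange of 3-hydroxyphenyl for tert-butyl on this aromatic carbon is a 1.8-fold lower number from compound 1 to compound 3 (0.25 log units; within the scatter). Among the compounds shown here, this shows what the earlier compounds could not: at this position, the six-membered aromatic ring and its hydroxyl can give way to a group with no ring and 0 hydrogen-bond donors with no change beyond the scatter. Nothing given here accounts for this outcome. Going by these compounds, whether an amine, a carboxylic acid or a longer chain on this carbon would move the number beyond the scatter remains open.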